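The source may hold more compounds than are shown below. What is called first, only, known or untested is meant among the compounds shown, and "the series" means these compounds.

Measured compounds in a functional assay on DLD-1 cells (Homo sapiens) for antiproliferative activity, read by CellTiter-Glo, with a stated time of 72 h; a lower number here means a stronger inhibitor, a higher number a weaker inhibitor:
- compound 1 `Cc1cc(C)c(S(=O)(=O)N2CCC(N3CCC(c4ccccc4)CC3)CC2)c(C)c1` gives 865 nM
- compound 2 `CC1CCN(C2CCN(S(=O)(=O)c3cccnc3F)CC2)CC1` gives > 5000 nM
- compound 3 `Cc1cc(C)c(S(=O)(=O)N2CCC(N3CCCCCC3)CC2)c(C)c1` gives 5.3 nM

The value for compound 2 is a limit of this assay, not a number; it sits at the limit of > 5000 nM in this assay, at which 1 of the 3 values shown sits. Among the two numbers that are actual readings, compound 1 has the higher one, and compound 3 lies far lower, a gap well beyond the scatter. Compound 1 and compound 3 share the same core and differ only in the amine that sits on the saturated ring carbon: compound 3 carries an azepane, compound 1 a phenyl-bearing piperidine.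

Compound 4 `Cc1cc(C)c(S(=O)(=O)N2CCC(N3CCC(Cc4ccccc4)CC3)CC2)c(C)c1` is not yet measured. It differs from compound 1 as follows: benzyl in place of phenyl on a saturated ring carbon. Among the measured compounds shown here, there is no measured pair in the set that covers this kind of change, so no step size can be read off directly. For the measured compounds named here, the only comparison available is that the amine substituent has a large effect here, as the values of compound 1 and compound 3 show. For compound 4 the expectation is a step of modest size at most, most likely within the scatter, in either direction: a 1.4-fold lower number from compound 1 to compound 4 (0.16 log units; within the scatter). Compound 4 is therefore estimated at 600 nM in this assay, with a range from 150 nM to 2500 nM.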

Compound 4, half-maximal inhibitory concentration: 3.5 nM
Beside the measured number, compound 4's estimate is 170-fold (2.23 log units) above it; the measured number lies below the stated range.
By their numbers in this assay, from the lowest: compounds 4 and 3 (each within the scatter of the next); then compound 1. At a limit, above all of these: compound 2.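

In this assay, among the compounds shown here, this place on the saturated ring, three ring bonds from the ring nitrogen, proves far more sensitive to a small edit than the earlier compounds could show: benzyl in place of phenyl gives a 250-fold lower number from compound 1 to compound 4 (2.39 log units; beyond the scatter), although both groups hold one six-membered aromatic ring of carbon only. An aromatic ring on this amine is therefore compatible with a low number, since compound 4 at 3.5 nM and compound 3 at 5.3 nM lie within the scatter of each other, and the high number of compound 1 belongs to the phenyl group rather than to aromatic substituents at this place in general. Nothing measured in this set bears on the cause of the step.

The compounds shown leave open how the number responds at this place to a phenethyl group, a benzoyl group or a phenoxy group, so it is unclear whether benzyl is a narrow optimum or the start of a broad tolerated range. From the compounds shown here alone, it is also open whether the benzyl result holds with a plain phenyl on the sulfonyl in place of the group in compound 4.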